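The source may report more compounds than this note shows. Statements on the series, on what has been measured and on what is new or still open speak of the compounds shown alone.

Compound 1 `COC(=O)c1ccc(NCc2cncn2Cc2ccccc2C(C)(C)C)cc1-c1ccccc1` is the anchor of this account. In a toxicity assay on NIH3T3 cells (Mus musculus) for cytotoxicity, read by resazurin assay (a lower number here means that less compound is needed, a higher number that more compound is needed for the effect), compound 1 stands at "not determined" (no result reported), so no number is attached to it, and its position can only be framed by the two other compounds that share its core. Compound 2 `Cc1cccc(-c2cccc(NCc3cncn3Cc3ccccc3)c2)c1C` reaches only a limit of this assay rather than a number, at > 1000 nM. Compound 3 `O=C(OC1CCCCC1)c1ccc(NCc2cncn2Cc2ccc(-c3ccccc3)cc2)cc1-c1ccccc1` likewise reaches only a limit of this assay, at > 10000 nM. Among the measured compounds shown here, of the three values shown, one therefore sits at the limit of > 1000 nM in this assay, at which 1 of the 3 values shown sits, and one at the limit of > 10000 nM in this assay, at which 1 of the 3 values shown sits, and no step between two measured compounds can be read from them.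

Compound 4 `COC(=O)c1ccc(NCc2cncn2Cc2ccc(F)cc2F)cc1-c1ccccc1` differs from compound 1 in a single place: 2,4-difluorophenyl in place of 2-(tert-butyl)phenyl on a saturated chain carbon bound to an aromatic nitrogen. For the measured compounds named here, no measured step covers this change, and neither limit gives a direction to lean on. The expectation for this assay is consequently no step beyond the scatter in either direction, with a further limit rather than a number the more likely outcome. Compound 4 is expected to give about 10000 nM in this assay, within a range from 2000 nM to 50000 nM.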

Compound 4, half-maximal effective concentration: > 1000 nM
Compound 4 was reported as a limit; the forecaster's own chance of this, stated with the estimate: 75%; the middle value lies beyond the limit too.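

In this assay, among the compounds shown here, compound 4 gives only a limit, > 1000 nM, and compound 1 has no number, so no step from compound 1 to compound 4 can be read. The compounds shown leave open whether the change from 2-(tert-butyl)benzyl to 2,4-difluorobenzyl shifts the concentration needed in this assay at all.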